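A few compounds are considered here, and "the series" means these few. Any claim that something is new, unique, unknown or untested is made for them only; others in the source may bear on it.

In an ADME assay on J774 cells (Mus musculus) for cytotoxicity (a higher number here means that more compound is needed for the effect, a lower number that less compound is needed), compound 1, whose structure is `COC(=O)c1c[nH]c2ccc(OC)cc2c1=O`, gives 6180 nM. Compound 2, with structure `CCOc1ccc2[nH]cc(C(=O)OC)c(=O)c2c1`, is reported in this assay only as a limit, > 20000 nM, not as a number. The change between these two compounds is methyl in place of hydrogen on a saturated chain carbon bound to an oxygen on an aromatic ring, and it made an at least 3.2-fold higher number from compound 1 to compound 2 (0.51 log units; beyond the scatter). Compound 3, with structure `CCc1cc2c(=O)c(C(=O)OC)c[nH]c2cc1OCCOc1ccccc1`, also reaches only a limit of this assay, > 20000 nM. How the core of compound 3 differs from the core of compound 1 is not broken down here. Still to be measured is compound 4, with structure `CCCc1cc2c(=O)c(C(=O)OC)c[nH]c2cc1OCCOc1ccccc1`. From compound 3 to compound 4 the change is methyl in place of hydrogen on a saturated chain carbon, two bonds along the chain from an aromatic carbon; this is the same kind of change as that from compound 1 to compound 2, but here the methyl enters on a saturated chain carbon two bonds along the chain from an aromatic carbon, whereas before it entered on one bound to an oxygen on an aromatic ring. Notable in this small set is the limit of > 20000 nM in this assay, at which 2 of the 3 values shown sit. For compound 4 the expected step is a step that the limit leaves unreadable from compound 3 to compound 4. Compound 4 is estimated to give 25000 nM, between 12000 nM and 60000 nM, most likely again as a limit.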

Compound 4, half-maximal effective concentration: > 20000 nM
Compound 4 gave a limit, no number; the forecaster's own chance of this, stated with the estimate: 80%; the middle value is on the limit's open side.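

Compound 3 and compound 4 both stop at a limit in this assay, not at a number, so no step between them can be read: the limit of > 20000 nM in this assay, at which 3 of the 4 values shown sit.

The compounds shown leave open where the true values of compound 3 and compound 4 lie, and whether going from ethyl to propyl changes the concentration needed at all.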